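Ethoxy for Methylamino at a Tolerated Limit

The source may report more compounds than this note shows. Statements on the series, on what has been measured and on what is new or still open speak of the compounds shown alone.

In a toxicity assay on HEK293 cells (Homo sapiens) for inhibition, read by resazurin assay, with a stated time of 24 h (a lower number here means that less compound is tolerated, a higher number that more compound is tolerated), compound 1 `O=C(NCc1ccc(F)cc1)c1ncc([N+](=O)[O-])[nH]1` gives > 100000 nM, which is a limit of the assay and not a number. Compound 2 `CNC(=O)c1nc([N+](=O)[O-])cn1Cc1ccc(OC(F)(F)F)cc1` gives > 100000 nM in this assay, and this too is a limit. Compound 2 therefore has no exact value of its own, and the data so far show (the limit of > 100000 nM in this assay, at which 2 of the 2 values shown sit).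

Compound 3 `CCOC(=O)c1nc([N+](=O)[O-])cn1Cc1ccc(OC(F)(F)F)cc1` departs from compound 2 at one place: ethoxy in place of methylamino on a carbonyl carbon. Put another way, methylcarbamoyl becomes ethoxycarbonyl. Among the compounds with values here, no measured pair shows what this change does in this assay, so any forecast is uncertain. Little or no change beyond the scatter is expected, and any real step is expected to run towards less compound being tolerated. The expected change is an at least 1.2-fold lower number from compound 2 to compound 3 (0.09 log units; that floor lies within the scatter). This expectation rests on compound 2 with its limit of > 100000 nM. For compound 3, the estimated half-maximal cytotoxic concentration is 80000 nM, with an expected range from 30000 nM to 150000 nM.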

Compound 3, half-maximal cytotoxic concentration: > 100000 nM
Compound 3 was reported as a limit; the forecaster's own chance of this, stated with the estimate: 70%; middle value at least 1.2-fold (0.09 log units) from the limit.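

Compound 2 and compound 3 are both reported only as limits in this assay and not as numbers, so the change from methylamino to ethoxy on the carbonyl carbon yields no readable step: the limit of > 100000 nM in this assay, at which 3 of the 3 values shown sit. The compounds shown leave open whether either compound has a measurable half-maximal cytotoxic concentration in these cells, and how this change would affect it.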